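This account rests on a few compounds, and the source may have more. Where it says the series, first, only, none or still open, it means among the compounds named here.

Three compounds sharing the core of compound 1 `Cc1cc(C(=O)NCc2ccccn2)nn1Cc1cc(Cl)ccc1OCc1ccccc1` have been measured in an assay on CHO-K1 cells for displacement of a labelled ligand from prostaglandin E2 receptor EP1 subtype (Homo sapiens); on this read-out higher numbers stand for weaker inhibition and lower numbers for stronger inhibition. Compound 1 gives 25.1 nM. Compound 2 `Cc1cc(C(=O)NCc2ccncc2)nn1Cc1cc(Cl)ccc1OCc1ccccc1` gives 79.4 nM, with a 3.2-fold higher number from compound 1 to compound 2 (0.50 log units; beyond the scatter). Compound 3 `Cc1cc(NC(=O)CC2CCCCC2)nn1Cc1cc(Cl)ccc1OCc1ccccc1` gives 6.31 nM, the lowest of the three: a 4.0-fold lower number from compound 1 to compound 3 (0.60 log units; beyond the scatter) and a 13-fold lower number from compound 2 to compound 3 (1.10 log units; beyond the scatter). Both steps into compound 3 exchange a carbamoyl arm for ((cyclohexylmethyl)carbonyl)amino, so that arm is tied to the strongest binding seen so far.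

Compound 4 `CCOC(=O)Nc1cc(C)n(Cc2cc(Cl)ccc2OCc2ccccc2)n1` keeps the amino-linked carbonyl but alters what sits on the carbonyl carbon: ethoxy in place of cyclohexylmethyl on a carbonyl carbon. Cut one bond further out, ((cyclohexylmethyl)carbonyl)amino becomes (ethoxycarbonyl)amino. Among the measured compounds shown here, no measured step tests this change; the steps from compound 1 and compound 2 only show that the amino-linked carbonyl side beats the two carbamoyl arms, not what the cyclohexylmethyl ring itself contributes. Since the ring leaves and an open-chain ethoxy enters, some weakening is expected, of uncertain size. Compound 4 is therefore estimated at 40 nM (range 8 nM to 200 nM), meaning an expected 6.3-fold higher number from compound 3 to compound 4 (0.80 log units; beyond the scatter) in this assay.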

Compound 4, half-maximal inhibitory concentration: 79.4 nM
Compound 4: middle estimate off by 2.0-fold (0.30 log units), on the low side; the measured number falls inside the stated range.
By their numbers in this assay, from the lowest: compound 3; then compound 1; then compounds 2 and 4 (each within the scatter of the next).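

In this assay, the step to ethoxy on the carbonyl carbon gives a 13-fold higher number from compound 3 to compound 4 (1.10 log units; beyond the scatter) even though the amino-linked carbonyl stays, so the strong binding of compound 3 depends on cyclohexylmethyl and not on that linkage alone. With (ethoxycarbonyl)amino on the aromatic carbon, the result is no change at the digits printed from compound 2 to compound 4 (within the scatter) against the ((pyridin-4-yl)methyl)carbamoyl arm and a 3.2-fold higher number from compound 1 to compound 4 (0.50 log units; beyond the scatter) against the ((pyridin-2-yl)methyl)carbamoyl arm, so this amino-linked arm has no edge over either carbamoyl arm. No measurement at hand explains these steps.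

As far as these compounds go, it remains open whether the ring of cyclohexylmethyl matters or simply the carbon count, which a straight hexyl chain on the carbonyl carbon would test. A propyl group there would separate the effect of the ethoxy oxygen from that of chain length.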